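This account rests on a few compounds, and the source may have more. Where it says the series, first, only, none or still open, it means among the compounds named here.

Measured so far:
compound 1, `COc1ccc(C(=O)Oc2cc3c(cc2C)[C@@H](C(C)C)CC=C3C)cc1`: 80.1% in a functional assay on MCF7 cells (Homo sapiens) for antiproliferative activity, read by sulforhodamine B assay, with a stated time of 48 h, tested at 50 uM; a lower number here means less inhibition, a higher number more inhibition at the concentration tested (going by the name of the read-out)
compound 2, `Cc1cc2c(C(C)C)ccc(C)c2cc1OC(=O)c1cccc(C(F)(F)F)c1`: compound 2 gives 41.5%
compound 3, `CC1=CC[C@H](C(C)C)c2cc(C)c(OC(=O)c3cccc(C)c3)cc21`: compound 3 gives 54.9%

Compound 3 stands second highest of the three numbers: compound 1 is higher by a step beyond the scatter, and compound 2 is lower by a gap beyond the scatter. Compound 2 differs from compound 3 both in its core and in its aryl group, so its value is noted only as a number, not as a step.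

Compound 4, `CC1=CC[C@H](C(C)C)c2cc(C)c(OC(=O)c3ccc([N+](=O)[O-])cc3)cc21`, differs from compound 3 in one place: 4-nitrophenyl in place of 3-methylphenyl on a carbonyl carbon.

Within the data shown here, the one measured step that bears on this change is a number 25.2 percentage points lower from compound 1 to compound 3 (beyond the scatter), a change of the aryl group on the same carbonyl carbon. There the 4-methoxyphenyl compound gave the higher number, and 3-methylphenyl the lower. Nothing measured carries a nitro group, so the direction for 4-nitrophenyl is inferred only from the one shown step, in which the number for a 4-substituted aryl is higher than that for 3-methylphenyl.

Compound 4 is therefore expected to give a somewhat higher number than compound 3 in this assay, with a wide range because no nitro-bearing comparison exists; the estimated step is a number 10.1 percentage points higher from compound 3 to compound 4 (beyond the scatter). The estimate for compound 4 is 65%, with a range from 45% to 85%.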

Compound 4, a percentage reported as inhibition, at one concentration (the size of the read-out at that concentration, not a potency): 72.9%
Beside the measured number, compound 4's estimate is 7.9 percentage points below it; low and high end bracket the measured number.
By their numbers in this assay, from the lowest: compound 2; then compound 3; then compounds 4 and 1 (each within the scatter of the next).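

In this assay, the aryl group on the carbonyl carbon proves sensitive to a second replacement of 3-methylphenyl, with a number 18 percentage points higher from compound 3 to compound 4 (beyond the scatter) for the change to 4-nitrophenyl. The comparison of the two other aryl groups on the shared core gives a number 7.2 percentage points lower from compound 1 to compound 4 (within the scatter) for nitro in place of methoxy on an aromatic carbon, so 4-nitrophenyl and 4-methoxyphenyl cannot be told apart here, although the entering groups differ in their atoms, and each stands beyond the scatter from 3-methylphenyl on this core. No measurement offered here explains why these aryl groups separate in this way.

The compounds shown leave open whether the separation follows the place of the substituent on the aryl ring or its identity, which a plain phenyl group, a 4-methylphenyl group or a 3-nitrophenyl group on the same core would help to settle. Also open, from the compounds shown here alone, are how an aryl ring carrying an amine or a carboxylic acid would read at this single tested concentration, and whether the same aryl changes carry over to the core of compound 2.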